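Capping the Last Free Hydroxy Group with Methyl

The source may report more compounds than this note shows. Statements on the series, on what has been measured and on what is new or still open speak of the compounds shown alone.

Of the compounds shown here, three have been tested so far in a functional assay on ileum (Cavia porcellus) for inhibition; on this read-out lower numbers stand for smaller maximal responses and higher numbers for larger maximal responses. Compound 1 `Oc1cc(O)cc(CCc2ccc(O)c(O)c2)c1` gives 53.7%, compound 2 `COc1cc(O)cc(CCc2ccc(O)cc2)c1` gives 85%, and compound 3 `COc1cccc(CCc2cc(O)cc(OC)c2)c1` gives 58.6%. Compound 3 thus holds the second highest of the three numbers: its value lies within the scatter of compound 1, while the higher number of compound 2 lies beyond the scatter. Compound 4 `COc1cccc(CCc2cc(OC)cc(OC)c2)c1` differs from compound 3 in one spot: methyl in place of hydrogen on an oxygen on an aromatic ring. Within the data shown here, no measured pair shows this change, so there is no basis for expecting a large shift in either direction. Compound 4 is therefore expected to give about 60%, with a range from 40% to 80%. The step of a number 1.4 percentage points higher from compound 3 to compound 4 (within the scatter) is expected to stay within the scatter.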

Compound 4, largest response reached (Emax), in percent of the reference or control that the assay uses: 75.6%
For compound 4 the middle estimate is 15.6 percentage points below the measured one; the measured number falls inside the stated range.
By their numbers in this assay, from the lowest: compounds 1 and 3 (each within the scatter of the next); then compounds 4 and 2 (each within the scatter of the next).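

Among these compounds, changing hydroxy to methoxy at this position gives a number 17 percentage points higher from compound 3 to compound 4 (beyond the scatter) in this assay and provides the first measured pair that differs in one place. At this position, then, a methyl cap on the oxygen is not a neutral swap on this read-out. Nothing measured here explains the rise.

This single pair leaves open whether the same change would shift the number similarly at other oxygens on the shared core. Also open, as far as these compounds go, is how a longer group on this oxygen, such as ethyl, or an amine in place of the methoxy would behave.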